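Replacing Benzyloxy with an Aryl Group: What to Expect

The compounds below may be only part of what the source reports. "The series", "measured", "known", "first", "only" and "open" are said of these compounds alone.

Compound 1 `O=C(NCc1ccc(C(F)(F)F)nc1N1CCCCC1)Nc1cccc2[nH]c(=O)ccc12` gives 0.75 nM in an assay on HEK cells for antagonist activity at transient receptor potential cation channel subfamily V member 1 (Homo sapiens), read by FLIPR; on this read-out lower numbers stand for stronger inhibition and higher numbers for weaker inhibition.
Compound 2 `O=C(NCc1ccc(C(F)(F)F)nc1OCc1ccccc1)Nc1cccc2[nH]c(=O)ccc12` gives 1.2 nM in this assay.

Among the compounds with values here, compound 2 shows the higher of the two numbers, yet the only measured step, a 1.6-fold higher number from compound 1 to compound 2 (0.20 log units; within the scatter), stays within the scatter. Compound 3 `CC(C)c1cccc(-c2nc(C(F)(F)F)ccc2CNC(=O)Nc2cccc3[nH]c(=O)ccc23)c1` differs from compound 2 by 3-isopropylphenyl in place of benzyloxy on an aromatic carbon. Within the data shown here, that lone step bears only loosely on the new change, since no measured compound carries a directly attached aryl group at that carbon; it does show that two quite different groups there gave numbers within the scatter of each other. The expected step is therefore small, a 1.3-fold higher number from compound 2 to compound 3 (0.10 log units; within the scatter), with no clear direction. Compound 3 is estimated at 1.5 nM, probably between 0.4 nM and 6 nM.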

Compound 3, half-maximal inhibitory concentration: 1.35 nM
Compound 3: the middle estimate sits 1.1-fold (0.05 log units) above what was measured; low and high end bracket the measured number.
By their numbers in this assay, from the lowest: compounds 1, 2 and 3 (each within the scatter of the next).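

In this assay, the aromatic carbon next to the ring nitrogen also accepts a directly attached aryl group, 3-isopropylphenyl, with no readable change from benzyloxy (a 1.1-fold higher number from compound 2 to compound 3 (0.05 log units; within the scatter)) or from piperidin-1-yl (a 1.8-fold higher number from compound 1 to compound 3 (0.26 log units; within the scatter)). All three groups therefore lie within the scatter of one another, even though the hydrogen-bond acceptor counted in benzyloxy is absent from 3-isopropylphenyl. Nothing available explains why these groups read alike. As far as these compounds go, how a primary amine, a carboxylic acid or a short methoxy group would read at this carbon remains open, so the limits of this tolerance are unknown.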